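Removing Bromo from the Compound 1 Scaffold

The source may report more compounds than this note shows. Statements on the series, on what has been measured and on what is new or still open speak of the compounds shown alone.

Measured in a functional assay on MIA PaCa-2 cells (Homo sapiens) for antiproliferative activity, read by sulforhodamine B assay, with a stated time of 48 h (on this read-out higher numbers stand for weaker inhibition and lower numbers for stronger inhibition), so far:
Compound 1 `COc1cc(C(=O)/C=C\Nc2ccc(-c3nc4cc(OC)c(OC)c(OC)c4s3)cc2)c(Br)c(OC)c1OC` gives 23200 nM
Compound 2 `COc1cc(C(=O)/C=C\Nc2ccc(-c3nc4cc(OC)c(OC)c(OC)c4s3)cc2C)c(Br)c(OC)c1OC` gives 24300 nM
Compound 3 `COc1ccc2nc(-c3ccc(N/C=C\C(=O)c4cc(OC)c(OC)c([N+](=O)[O-])c4)c(C)c3)sc2c1` gives 12000 nM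

In this assay the value of compound 1 lies within the scatter of the values of compound 2 and compound 3. The next compound, compound 4 `COc1cc(C(=O)/C=C\Nc2ccc(-c3nc4cc(OC)c(OC)c(OC)c4s3)cc2)cc(OC)c1OC`, has not yet been measured. It carries hydrogen in place of bromo on an aromatic carbon, ortho to a large group. Among the measured compounds shown here, the only measured step (a 1.0-fold higher number from compound 1 to compound 2 (0.02 log units; within the scatter)) is methyl in place of hydrogen on an aromatic carbon. It lies within the scatter, but it is a different change, so it bears on this one only weakly. For the measured compounds named here, no measured pair shows bromo being lost. No step beyond the scatter is therefore expected in this assay, and the data suggest no direction. The expected step (a 1.2-fold lower number from compound 1 to compound 4 (0.06 log units; within the scatter)) is correspondingly small. Compound 4 is estimated at 20000 nM, with an expected range from 6000 nM to 50000 nM overall.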

Compound 4, half-maximal inhibitory concentration: 29100 nM
Estimate against measurement, compound 4: 1.5-fold (0.16 log units) below; measured number inside the range.
By their numbers in this assay, from the lowest: compounds 3, 1, 2 and 4 (each within the scatter of the next, the first and the last beyond it).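

In this assay, among the compounds shown here, hydrogen in place of bromo on this aromatic carbon, ortho to a large group, gives a 1.3-fold higher number from compound 1 to compound 4 (0.10 log units; within the scatter) and this is the first measured pair in which bromo is lost. The step lies within the scatter, so on this read-out compound 1 and compound 4 cannot be told apart, and the bromo shows no measurable contribution at this position. Nothing available explains this result or bears on the role of this position.

From the compounds shown here alone, it remains open whether another group on this carbon, such as an amine, a hydroxyl or a carboxylic acid, would produce a step beyond the scatter. Going by these compounds, it is also open whether losing bromo would have as small an effect on another core.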